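The compounds below may be only part of what the source reports. "The series", "measured", "known", "first", "only" and "open" are said of these compounds alone.

Measured so far in a functional assay (aorta) with Rattus norvegicus as the target; a lower number here means that less compound is needed, a higher number that more compound is needed for the effect: compound 1 `CC1(C)CC(NC(=O)Nc2ccccc2)c2cc(Cl)ccc2O1` gives 7800 nM, and compound 2 `CC1(C)CC(NC(=O)Nc2ccccc2)c2cc(Br)ccc2O1` gives 2300 nM. Compound 3 `CC1(C)CC(NC(=O)Nc2cccc(Cl)c2)c2cc(Cl)ccc2O1` gives only a limit of this assay, > 30000 nM, and no number.

From compound 1 to compound 2 the change is bromo in place of chloro on an aromatic carbon, and the step is a 3.4-fold lower number from compound 1 to compound 2 (0.53 log units; beyond the scatter). The core of compound 3 differs from that of compound 1 by chloro in place of hydrogen on an aromatic carbon, a step of an at least 3.8-fold higher number from compound 1 to compound 3 (0.58 log units; beyond the scatter). Compound 4 `CC1(C)CC(NC(=O)Nc2cccc(Cl)c2)c2cc(Br)ccc2O1` differs from compound 3 by bromo in place of chloro on an aromatic carbon, the same change seen from compound 1 to compound 2. Compound 3 stands at the limit of > 30000 nM in this assay, at which 1 of the 3 values shown sits, so the starting point is uncertain. The step to compound 4 is expected to be an at least 1.5-fold lower number from compound 3 to compound 4 (0.17 log units; that floor lies within the scatter), resting on a 3.4-fold lower number from compound 1 to compound 2 (0.53 log units; beyond the scatter). Compound 4 is therefore estimated at 20000 nM, between 6000 nM and 60000 nM.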

Compound 4, half-maximal effective concentration: > 30000 nM
Compound 4: only a limit was reported; the forecaster's own chance of this, stated with the estimate: 45%; middle value at least 1.5-fold (0.17 log units) from the limit.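

In this assay compound 4 gives > 30000 nM, which is a limit of the assay and not a number. Chloro in place of hydrogen on an aromatic carbon gives an at least 13-fold higher number from compound 2 to compound 4 (1.11 log units; beyond the scatter), so this change raises the number on both cores shown. The step between compound 3 and compound 4 lies between two limits and cannot be read, so it is unknown whether bromo in place of chloro still lowers the number once the added chloro is present, and the chloro change cannot be compared in size across the two cores: the same change on two cores in this assay, an at least 3.8-fold higher number (0.58 log units; beyond the scatter) from compound 1 to compound 3 and an at least 13-fold higher number (1.11 log units; beyond the scatter) from compound 2 to compound 4; the limit leaves it open whether they differ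

The compounds shown leave open whether a fluoro or a methoxy group in place of the added chloro would bring the read-out back to a measurable number. They also leave open whether iodo in place of bromo on the core of compound 2 would lower the number further.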